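This account rests on a few compounds, and the source may have more. Where it says the series, first, only, none or still open, it means among the compounds named here.

Measured so far:
compound 1 `O=C(NO)c1ccc(CN(Cc2ccccc2)S(=O)(=O)c2c(F)c(F)c(F)c(F)c2F)cc1` — 9 nM
compound 2 `O=C(NO)c1ccc(CN(Cc2ccc(F)cc2)S(=O)(=O)c2c(F)c(F)c(F)c(F)c2F)cc1` — 13 nM

In an assay on isolated protein for inhibition of protein deacetylase HDAC6 (Homo sapiens), read by mobility shift assay (on this read-out lower numbers stand for stronger inhibition and higher numbers for weaker inhibition), compound 1 gives 9 nM; compound 2 gives 13 nM, and the step of a 1.4-fold higher number from compound 1 to compound 2 (0.16 log units; within the scatter) is within the scatter, so the two stand level. Compound 3 `O=C(NO)c1ccc(CN(Cc2ccccc2)S(=O)(=O)c2cc(F)c(F)c(F)c2F)cc1` differs from compound 1 by hydrogen in place of fluoro on an aromatic carbon. For the measured compounds named here, the only measured step, from compound 1 to compound 2, touches another part of the molecule and was within the scatter; no measured step removes a fluoro from the 2,3,4,5,6-pentafluorophenyl group. For compound 3 a step of a 1.6-fold higher number from compound 1 to compound 3 (0.19 log units; within the scatter) is expected, within the scatter. The estimate for compound 3 is 14 nM, range 5 nM to 40 nM.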

Compound 3, half-maximal inhibitory concentration: 5 nM
Beside the measured number, compound 3's estimate is 2.8-fold (0.45 log units) above it, within the range that was stated.
By their numbers in this assay, from the lowest: compounds 3, 1 and 2 (each within the scatter of the next, the first and the last beyond it).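

In this assay the change from 2,3,4,5,6-pentafluorophenyl to 2,3,4,5-tetrafluorophenyl gives a 1.8-fold lower number from compound 1 to compound 3 (0.26 log units; within the scatter) and leaves the two compounds level. At this position, ortho to a large group, the full set of five fluoro groups is therefore not needed to keep the number in the same range. No supporting measurement accounts for this outcome.

Open, going by these compounds, is whether a chloro, methoxy or amino group at this position would also stay level with hydrogen and fluoro. Also open, on these data alone, is how many further fluoro groups on this ring can give way to hydrogen.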